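A few compounds are considered here, and "the series" means these few. Any claim that something is new, unique, unknown or untested is made for them only; others in the source may bear on it.

Measured so far:
Compound 1, `CC#CC(CC(=O)O)c1ccc(OCC2COc3ccc(Cl)cc3O2)cc1` — 100 nM
Compound 2, `CC#C[C@@H](CC(=O)O)c1ccc(OC[C@H]2COc3ccc(Cl)cc3O2)cc1` — 50 nM

In a functional assay on HEK293 cells for agonist activity at Free fatty acid receptor 1 (Homo sapiens), read by fluorescence and calcium flux, with a stated time of 10 min (on this read-out lower numbers stand for an effect already at smaller amounts and higher numbers for an effect only at larger amounts of compound), compound 2 gives 50 nM, the lowest of the two numbers; its nearest neighbour is compound 1 with 100 nM, and the step of a 2.0-fold lower number from compound 1 to compound 2 (0.30 log units; within the scatter) is within the scatter, so the two cannot be ranked against each other. Compound 3, `CC#C[C@@H](CC(=O)O)c1ccc(OC[C@H]2COc3ccc(S(C)(=O)=O)cc3O2)cc1`, differs from compound 2 in one place: methylsulfonyl in place of chloro on an aromatic carbon. Going by the values given here, no measured step bears on this exchange. Among the compounds with values here, the single step from compound 1 to compound 2 concerns only (the fact that one of compounds 1 and 2 is drawn with a defined configuration and the other without, at the place where they differ), which says nothing about a methylsulfonyl in place of chloro. The expectation for compound 3 therefore rests on compound 2 alone and carries a wide range. Compound 3 is expected to give 100 nM, between 25 nM and 400 nM, which means an expected step of a 2.0-fold higher number from compound 2 to compound 3 (0.30 log units; within the scatter), in no particular direction beyond the scatter.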

Compound 3, half-maximal effective concentration: 27200 nM
Beside the measured number, compound 3's estimate is 270-fold (2.43 log units) below it; the measured number lies above the stated range.
By their numbers in this assay, from the lowest: compounds 2 and 1 (each within the scatter of the next); then compound 3.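

Exchanging chloro for methylsulfonyl on this aromatic carbon gives a 540-fold higher number from compound 2 to compound 3 (2.74 log units; beyond the scatter) in this assay, so the position is far from indifferent to the group it carries. Going by these compounds alone, the earlier pair differed only in how configuration was drawn and stayed within the scatter, so this is the first sign that one substituent on the shared core can separate an effect at small amounts from one seen only at much larger amounts. Nothing available explains the size of this step.

From the compounds shown here alone, with only chloro and methylsulfonyl compared here, it stays open whether the loss follows the 4 heavy atoms of the entering group, its 2 hydrogen-bond acceptors, or something else. Going by these compounds, how a methyl or a methoxy group would behave on this same aromatic carbon also remains unknown.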